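The source may hold more compounds than are shown below. What is called first, only, known or untested is meant among the compounds shown, and "the series" means these compounds.

In a functional assay on MCF7 cells (Homo sapiens) for cytotoxicity, read by MTT assay, with a stated time of 4 h (a higher number here means a weaker inhibitor, a lower number a stronger inhibitor), compound 1 (`CCCCCCCCCCCC(=O)OC[C@H]1O[C@@H](O[C@@H]2OC=C(C(=O)OC)[C@H]3C[C@H](OC(C)=O)[C@H](C)[C@@H]23)[C@H](OC(C)=O)[C@@H](OC(C)=O)[C@@H]1OC(C)=O`) gives 0.24 ug/mL. Among the compounds with values here, compound 2 (`C=CC(=O)OC[C@H]1O[C@@H](O[C@@H]2OC=C(C(=O)OC)[C@H]3C[C@H](OC(C)=O)[C@H](C)[C@@H]23)[C@H](OC(C)=O)[C@@H](OC(C)=O)[C@@H]1OC(C)=O`) is recorded as "not active" (no number reported), so it has no single number to step from. Compound 3 (`COC(=O)C1=CO[C@@H](O[C@@H]2O[C@H](COC(=O)C=C(C)C)[C@@H](OC(C)=O)[C@H](OC(C)=O)[C@H]2OC(C)=O)[C@@H]2[C@@H](C)[C@@H](OC(C)=O)C[C@H]12`) differs from compound 2 by 2-methylprop-1-en-1-yl in place of vinyl on a carbonyl carbon, with 2-methylprop-1-en-1-yl in place of vinyl on a carbonyl carbon. Within the data shown here, no measured step covers this change, so its size in this assay is only an expectation: a modest move towards stronger inhibition, with compound 3 still expected to be weaker than compound 1 at 0.24 ug/mL. For compound 3 the estimated value is 15 ug/mL, with an expected range of 2 ug/mL to 100 ug/mL.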

Compound 3, half-maximal inhibitory concentration: 1 ug/mL
Estimate against measurement, compound 3: 15-fold (1.18 log units) above; the measured number lies below the stated range.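

In this assay, activity at this carbonyl carbon does not need the undecyl chain: with 2-methylprop-1-en-1-yl in place of vinyl, compound 3 gives 1 ug/mL, while compound 2 has no number, so the step from it cannot be read. Against the long chain, the change is a 4.2-fold higher number from compound 1 to compound 3 (0.62 log units; beyond the scatter), a modest loss. Nothing available bears on the reason for either result.

Open, from the compounds shown here alone, is how a shorter saturated chain such as propyl, or a phenyl group, on this carbonyl carbon would read in this assay.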